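Cytotoxicity notes on the shared core: compound 3 to compound 4

The compounds below may be only part of what the source reports. "The series", "measured", "known", "first", "only" and "open" are said of these compounds alone.

Three members of the series have been run in an ADME assay on CRL8155 cells (Homo sapiens) for cytotoxicity, read by resazurin assay, with a stated time of 72 h; a higher number here means that more compound is needed for the effect, a lower number that less compound is needed. Compound 1 `O=C(NCCCCO)Nc1nc2ccc(C(=O)c3ccccc3)cc2[nH]1` gives only a limit of the assay, > 30000 nM. Compound 2 `O=C(NCCC1CCNCC1)Nc1nc2ccc(C(=O)c3ccccc3)cc2[nH]1` likewise stops at a limit, > 30000 nM. Compound 3 `Nc1nc2ccc(C(=O)c3ccccc3)cc2n1C[C@H]1CCCN1` also reaches only a limit, > 30000 nM. Going by the values given here, the one step between compounds that differ in a single place, a step that the two limits leave unreadable from compound 1 to compound 2, therefore has no readable size; the whole picture so far is the limit of > 30000 nM in this assay, at which 3 of the 3 values shown sit.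

Compound 4 `CC(C)Cn1c(N)nc2ccc(C(=O)c3ccccc3)cc21` differs from compound 3 by isopropyl in place of pyrrolidin-2-yl on a saturated chain carbon bound to an aromatic nitrogen. Among the compounds with values here, no measured step in this assay bears on this change, and the single step that exists gives no size. On the numbers shown, compound 3 stands at the limit together with the other two compounds, so neither direction nor size can be drawn from the series. The expected step, a step that the limit leaves unreadable from compound 3 to compound 4, is therefore none beyond the scatter, with the outcome most likely again a limit. The estimate for compound 4 in this assay is 40000 nM, ranging from 15000 nM to 100000 nM.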

Compound 4, half-maximal effective concentration: > 30000 nM
Compound 4: only a limit was reported; the forecaster's own chance of this, stated with the estimate: 75%; the middle value does not contradict the limit.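

In this assay compound 4 gives only a limit, > 30000 nM, so no size can be read for the step from compound 3 to compound 4. The compounds shown leave open whether any change on the shared core gives a readable value, since the series rests at one point: the limit of > 30000 nM in this assay, at which 4 of the 4 values shown sit.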